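Aryl swap on the shared core toward compound 4

The source may hold more compounds than are shown below. What is called first, only, known or untested is meant among the compounds shown, and "the series" means these compounds.

Compound 1 `Cc1ccnc(NC(c2ccc3cccnc3c2O)c2c(F)cccc2Cl)c1` reaches in an assay for inhibition of protein disulfide-isomerase (Homo sapiens), with a stated time of 1 h (on this read-out lower numbers stand for stronger inhibition and higher numbers for weaker inhibition), only the limit > 40000 nM, so no number is known for it. Compound 1 therefore stands apart from the other two values, as shown by the limit of > 40000 nM in this assay, at which 1 of the 3 values shown sits. Compound 3 `CCc1ccc(C(Nc2ccccn2)c2ccc3cccnc3c2O)cc1` keeps the core of compound 1 with a different aryl group; in this assay compound 3 gives 170 nM. Compound 2 `Oc1ccc2[nH]ncc2c1C(c1ccc(-c2cncnc2)cc1)N1CCCCC1`, built on another core, gives 830 nM in this assay. Compound 4 `COc1ccc(C(Nc2cc(C)ccn2)c2ccc3cccnc3c2O)cc1O` differs from compound 1 by 3-hydroxy-4-methoxyphenyl in place of 2-chloro-6-fluorophenyl on a saturated chain carbon bound to an aromatic carbon and a nitrogen on an aromatic ring. Among the measured compounds shown here, no measured step joins these two compounds. A move toward stronger inhibition in this assay is expected, estimated as an at least 26-fold lower number from compound 1 to compound 4 (1.42 log units; beyond the scatter), because compound 3 with the same core gives 170 nM. Compound 4 is expected to give about 1500 nM, within 150 nM to 20000 nM.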

Compound 4, half-maximal inhibitory concentration: 150 nM
The estimate for compound 4 lay 10-fold (1.00 log units) above the measured number; measured number inside the range.
By their numbers in this assay, from the lowest: compounds 4 and 3 (each within the scatter of the next); then compound 2. At a limit, above all of these: compound 1.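

With 3-hydroxy-4-methoxyphenyl in place of 2-chloro-6-fluorophenyl, this assay gives an at least 260-fold lower number from compound 1 to compound 4 (2.42 log units; beyond the scatter) on the shared core, the only one-place comparison shown so far. On this core, the aryl group at this position separates a limit from a measured number. From the compounds shown here alone, the step has only a lower bound, and its full size stays unknown, since compound 1 rests on a limit of the assay: the limit of > 40000 nM in this assay, at which 1 of the 4 values shown sits.

Whether the hydroxy or the methoxy group alone accounts for the step remains open, as does the effect of an amine or a carboxylic acid on this aryl ring.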